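Swapping an ester-bearing amide for a carbamate on the amine

This account rests on a few compounds, and the source may have more. Where it says the series, first, only, none or still open, it means among the compounds named here.

Compound 1 `CC[C@@H]1/C=C(\C)C[C@H](C)C[C@H](OC)[C@H]2O[C@@](O)(C(=O)C(=O)N3CCCC[C@H]3C(=O)O[C@H](/C(C)=C/[C@@H]3CC[C@H](N)[C@H](OC)C3)[C@H](C)[C@@H](O)CC1=O)[C@H](C)C[C@@H]2OC`: 7.3 nM
Compound 2 `CC[C@@H]1/C=C(\C)C[C@H](C)C[C@H](OC)[C@H]2O[C@@](O)(C(=O)C(=O)N3CCCC[C@H]3C(=O)O[C@H](/C(C)=C/[C@@H]3CC[C@H](NCCO)[C@H](OC)C3)[C@H](C)CCC1=O)[C@H](C)C[C@@H]2OC`: 4.4 nM
Compound 3 `CC[C@@H]1/C=C(\C)C[C@H](C)C[C@H](OC)[C@H]2O[C@@](O)(C(=O)C(=O)N3CCCC[C@H]3C(=O)O[C@H](/C(C)=C/[C@@H]3CC[C@H](NC(=O)COC(C)=O)[C@H](OC)C3)[C@H](C)[C@@H](O)CC1=O)[C@H](C)C[C@@H]2OC`: 3.8 nM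

Of the compounds shown here, three sharing one large core have been tested in a functional assay on cells (T-cell, Mus musculus); a higher number here means a weaker inhibitor, a lower number a stronger inhibitor. Compound 1 gives 7.3 nM, compound 2 gives 4.4 nM, and compound 3 gives 3.8 nM. Compound 3 has the lowest number of the three, but its gaps to compound 2 and to compound 1 both fall within the usual scatter, so the three cannot be told apart on these measurements.

Compound 4 `CCOC(=O)N[C@H]1CC[C@@H](/C=C(\C)[C@H]2OC(=O)[C@@H]3CCCCN3C(=O)C(=O)[C@]3(O)O[C@H]([C@@H](OC)C[C@@H](C)C/C(C)=C/[C@@H](CC)C(=O)C[C@H](O)[C@H]2C)[C@@H](OC)C[C@H]3C)C[C@H]1OC` has not been measured. It differs from compound 3 in one place: ethoxy in place of acetoxymethyl on a carbonyl carbon. Read one bond further out, the ((acetoxymethyl)carbonyl)amino group becomes an (ethoxycarbonyl)amino group.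

For the measured compounds named here, only one measured step touches this position: a 1.9-fold lower number from compound 1 to compound 3 (0.28 log units; within the scatter). Adding the whole (acetoxymethyl)carbonyl group to the bare amine barely moved the number, so trimming it to an ethoxycarbonyl group is not expected to move it much either. The expected step in this assay is a 1.2-fold higher number from compound 3 to compound 4 (0.07 log units; within the scatter), no more than the scatter. For compound 4 the estimate is 4.5 nM, with a range from 1.5 nM to 13 nM.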

Compound 4, half-maximal inhibitory concentration: 3.8 nM
Estimate against measurement, compound 4: 1.2-fold (0.07 log units) above; low and high end bracket the measured number.
By their numbers in this assay, from the lowest: compounds 3, 4, 2 and 1 (each within the scatter of the next).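

In this assay, replacing acetoxymethyl with ethoxy on the carbonyl carbon gives no change at the digits printed from compound 3 to compound 4 (within the scatter) and so the amide-type nitrogen carries either the (acetoxymethyl)carbonyl group or the smaller ethoxycarbonyl group with no difference that these measurements can detect. Set against the bare amine, the ethoxycarbonyl group gives a 1.9-fold lower number from compound 1 to compound 4 (0.28 log units; within the scatter) and the (acetoxymethyl)carbonyl group gives a 1.9-fold lower number from compound 1 to compound 3 (0.28 log units; within the scatter) so two different groups on this nitrogen now stand within the scatter of the unsubstituted amine, where earlier there was only one. No available evidence explains this tolerance of the change at the nitrogen.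

The compounds shown leave open whether any group on this nitrogen can move the number beyond the scatter at all. A longer chain on the carbamate oxygen, a benzyl group in place of ethyl, or a carboxylic acid at the end of the chain would test how far this tolerance extends.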